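This account rests on a few compounds, and the source may have more. Where it says the series, first, only, none or still open, it means among the compounds named here.

Measured so far in an ADME assay on cells (Hepatocyte, Homo sapiens) for metabolic stability, with a stated time of 30 min; a lower number here means that less of the compound is left, a higher number that more of the compound is left:
compound 1 `Cc1ccc(C(=O)OC2CCC(CN3CCN(c4cc(=O)c5cc(C(F)(F)F)cc([N+](=O)[O-])c5s4)CC3)CC2)cc1` gives 9.7%
compound 2 `O=C(OC1CCC(CN2CCN(c3cc(=O)c4cc(C(F)(F)F)cc([N+](=O)[O-])c4s3)CC2)CC1)c1ccco1` gives 1%
compound 3 `Nc1cc(C(F)(F)F)cc2c(=O)cc(N3CCN(CC4CCC(O)CC4)CC3)sc12` gives 72.9%

Compound 2 lies within the scatter of compound 1, and far under compound 3, a gap beyond the scatter. Compound 4 `COc1ccc(C(=O)OC2CCC(CN3CCN(c4cc(=O)c5cc(C(F)(F)F)cc([N+](=O)[O-])c5s4)CC3)CC2)cc1` changes one place of compound 2: 4-methoxyphenyl in place of furan-2-yl on a carbonyl carbon. Among the compounds with values here, the only measured step at that place is a number 8.7 percentage points lower from compound 1 to compound 2 (within the scatter), which stayed within the scatter. Within the data shown here, compound 3 differs in more than one place and offers no such step. No step beyond the scatter is therefore expected in this assay here. The expected step is a number 4 percentage points higher from compound 2 to compound 4 (within the scatter), within the scatter. Compound 4 is estimated at 5%, with a range of 1% to 15%.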

Compound 4, percent of the compound remaining: 12.2%
The estimate for compound 4 lay 7.2 percentage points below the measured number, within the range that was stated.
By their numbers in this assay, from the lowest: compounds 2, 1 and 4 (each within the scatter of the next, the first and the last beyond it); then compound 3.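

In this assay, this position now shows a modest change beyond the scatter, with 4-methoxyphenyl in place of furan-2-yl on the carbonyl carbon: a number 11.2 percentage points higher from compound 2 to compound 4 (beyond the scatter). Methoxy in place of methyl on the aromatic carbon stays within the scatter: a number 2.5 percentage points higher from compound 1 to compound 4 (within the scatter). Nothing given here explains either step.

On these data alone, it remains open whether an amine or a carboxylic acid on the aromatic ring would shift the number at this position. A longer chain in place of the ring is equally untested by these compounds.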